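This account rests on a few compounds, and the source may have more. Where it says the series, first, only, none or still open, it means among the compounds named here.

Compound 1 `O=c1ccc(CCO)nn1Cc1ccccc1` carries a hydroxy on a short chain off the shared core. In a functional assay on aorta (Rattus norvegicus) (on this read-out lower numbers stand for stronger inhibition and higher numbers for weaker inhibition), compound 1 gives > 100000 nM, which is a limit of the assay rather than a number, as noted in the limit of > 100000 nM in this assay, at which 1 of the 3 values shown sits. For comparison, compound 2 `Cn1nc(CCO[Si](c2ccccc2)(c2ccccc2)C(C)(C)C)ccc1=O` gives 47000 nM in this assay, and compound 3 `Cn1nc(CCCOCc2ccccc2)ccc1=O` gives 76400 nM. Compound 4 `O=c1ccc(CCCO)nn1Cc1ccccc1` is not yet measured. The change from compound 1 to compound 4 is hydroxymethyl in place of hydroxy on a saturated chain carbon, two bonds along the chain from an aromatic carbon. For the measured compounds named here, no measured step of this kind is available. The step expected is a number no higher from compound 1 to compound 4 (the limit leaves the size open), staying within the scatter and without a clear direction. Compound 4 is therefore estimated at 100000 nM, with a range from 40000 nM to 250000 nM.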

Compound 4, half-maximal inhibitory concentration: > 100000 nM
Compound 4 was reported as a limit; the forecaster's own chance of this, stated with the estimate: 55%; the middle value sits exactly at the limit.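

Compound 1 and compound 4 are both limits in this assay, so no step between them can be read: the limit of > 100000 nM in this assay, at which 2 of the 4 values shown sit.

What hydroxymethyl in place of hydroxy does to inhibition on the shared core stays open in the compounds shown.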